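From hydroxy to methoxy on compound 2

The compounds below may be only part of what the source reports. "The series", "measured", "known", "first", "only" and "open" are said of these compounds alone.

Measured in an ADME assay on MDCK cells (Canis lupus familiaris) for cytotoxicity, read by MTT assay, with a stated time of 72 h; on this read-out lower numbers stand for stronger inhibition and higher numbers for weaker inhibition:
- compound 1 `COc1ccc(/C=C/C(=O)CC(C)=O)cc1`: 41600 nM
- compound 2 `Cc1cc(/C=C/c2ccc(O)c(O)c2)on1`: 11600 nM
- compound 3 `CC(=O)CC(=O)/C=C/c1ccc(O)cc1`: 30600 nM

Compound 2, at 11600 nM, has the lowest number of the three, and its gaps to compound 1 and compound 3 lie beyond the scatter. Compound 4 `COc1cc(/C=C/c2cc(C)no2)ccc1O` differs from it in one place: methyl in place of hydrogen on an oxygen on an aromatic ring. Within the data shown here, only one measured step bears on this, and it runs the opposite way on another core: a 1.4-fold lower number from compound 1 to compound 3 (0.13 log units; within the scatter). Read backwards, this single step points to no change beyond the scatter in this assay, with at most a slight rise. The expected step is a 1.3-fold higher number from compound 2 to compound 4 (0.11 log units; within the scatter). Compound 4 is estimated at 15000 nM, with an expected range of 6500 nM to 35000 nM.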

Compound 4, half-maximal inhibitory concentration: 29800 nM
Beside the measured number, compound 4's estimate is 2.0-fold (0.30 log units) below it; measured number inside the range.
By their numbers in this assay, from the lowest: compound 2; then compounds 4, 3 and 1 (each within the scatter of the next).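

In this assay, among these compounds, changing hydroxy to methoxy on an oxygen on an aromatic ring gives a 2.6-fold higher number from compound 2 to compound 4 (0.41 log units; beyond the scatter), the first step of this change that lies beyond the scatter. On this core, then, the hydroxy makes a measurable difference, which the earlier step on the core of compound 1 could not show. The change points the same way on both cores, and the two steps cannot be told apart: the same change on two cores in this assay, a 1.4-fold lower number (0.13 log units; within the scatter) from compound 1 to compound 3 and a 2.6-fold lower number (0.41 log units; beyond the scatter) from compound 4 to compound 2, 1.9-fold (0.28 log units) apart, within the scatter of two such steps

The compounds shown leave open whether ethyl or a longer chain on this oxygen would raise the number further. They also leave open what an amine in place of the hydroxy would do.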